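The source may hold more compounds than are shown below. What is called first, only, known or untested is meant among the compounds shown, and "the series" means these compounds.

Compound 3 `Cn1c(N2N=C(c3ccccc3)CC2c2ccc(F)cc2)nc(-c2ccccc2)c(C#N)c1=O` is the second highest of the three numbers in a functional assay on A549 cells (Homo sapiens) for antiproliferative activity, with a stated time of 72 h; on this read-out lower numbers stand for stronger inhibition and higher numbers for weaker inhibition. Its nearest neighbour is compound 1 `Cn1c(N2N=C(c3ccccc3)CC2c2ccccc2)nc(-c2ccccc2)c(C#N)c1=O`; the step of a 1.3-fold lower number from compound 1 to compound 3 (0.13 log units; within the scatter) lies within the scatter, so the two are indistinguishable here, with compound 1 at 52900 nM and compound 3 at 39200 nM. Its furthest neighbour is compound 2 `COc1ccc(C2CC(c3ccccc3)=NN2c2nc(-c3ccccc3)c(C#N)c(=O)n2C)cc1`, at 1760 nM, reached through a 22-fold higher number from compound 2 to compound 3 (1.35 log units; beyond the scatter).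

Compound 4 `Cc1ccc(C2=NN(c3nc(-c4ccccc4)c(C#N)c(=O)n3C)C(c3ccc(F)cc3)C2)cc1` differs from compound 3 by methyl in place of hydrogen on an aromatic carbon, and this methyl enters on a different phenyl ring from the one that carries the fluoro of compound 3. The steps measured so far only concern that other ring: a 30-fold lower number from compound 1 to compound 2 (1.48 log units; beyond the scatter) shows that a para group there can matter greatly, whereas a 1.3-fold lower number from compound 1 to compound 3 (0.13 log units; within the scatter) shows it need not. For the measured compounds named here, no measured step tests a methyl, nor this ring, so the expected step of a 2.0-fold lower number from compound 3 to compound 4 (0.29 log units; within the scatter) is modest and uncertain in direction. Compound 4 is therefore estimated at 20000 nM, within 5000 nM to 60000 nM.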

Compound 4, half-maximal inhibitory concentration: 2000 nM
Beside the measured number, compound 4's estimate is 10-fold (1.00 log units) above it, outside the stated range (below it).
By their numbers in this assay, from the lowest: compounds 2 and 4 (each within the scatter of the next); then compounds 3 and 1 (each within the scatter of the next).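

The step of a 20-fold lower number from compound 3 to compound 4 (1.29 log units; beyond the scatter) in this assay shows that the phenyl ring without the fluoro also responds strongly: a single methyl, para to a large group, is enough for a large change. Earlier steps tested only the other ring, where the methoxy step a 30-fold lower number from compound 1 to compound 2 (1.48 log units; beyond the scatter) was large and the fluoro step a 1.3-fold lower number from compound 1 to compound 3 (0.13 log units; within the scatter) was not, so both rings can now be said to affect this read-out. No available evidence explains why the methyl has this effect.

The compounds shown leave open whether the methyl would have the same effect without the fluoro on the other ring, since phenyl to 4-methylphenyl appears here only once. They also leave open how an ethyl chain, a hydroxyl or an amine would behave at this position.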